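Adding Methoxy to the Methylated Core: Expected Inhibition

The source may report more compounds than this note shows. Statements on the series, on what has been measured and on what is new or still open speak of the compounds shown alone.

Measured so far:
compound 1, `COc1cccc(-c2cc3[nH]nc(N)c3c(=O)[nH]2)c1`, 2%
compound 2, `Cn1nc(N)c2c(=O)[nH]c(-c3ccccc3)cc21`, 4%

Both compounds were tested in an assay on isolated protein for inhibition of RAC-beta serine/threonine-protein kinase (Homo sapiens), read by mobility shift assay, tested at 30 uM; on this read-out lower numbers stand for less inhibition and higher numbers for more inhibition at the one concentration tested (going by the name of the read-out). Compound 1 gives 2% and compound 2 gives 4%; the two numbers sit within the usual scatter of each other, so compound 2 stands alongside compound 1 with nothing to separate them. Going by the values given here, no step between measured compounds is available.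

Compound 3, `COc1cccc(-c2cc3c(c(N)nn3C)c(=O)[nH]2)c1`, has not yet been measured. It differs from compound 2 in one place: methoxy in place of hydrogen on an aromatic carbon. Compound 1 already carries this methoxy group on its own core and shows essentially no inhibition, so the change is expected to bring no step beyond the scatter in this assay. The expected step is no change at the digits printed from compound 2 to compound 3 (within the scatter), which means compound 3 is estimated at 4%, in a range from -5% to 13%.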

Compound 3, a percentage reported as inhibition, at one concentration (the size of the read-out at that concentration, not a potency): 1%
Compound 3: middle estimate off by 3 percentage points, on the high side; low and high end bracket the measured number.
By their numbers in this assay, from the lowest: compounds 3, 1 and 2 (each within the scatter of the next).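

In this assay, methoxy in place of hydrogen on an aromatic carbon, meta to a large group, can now be read as a single change on the core carrying the methyl group (a number 3 percentage points lower from compound 2 to compound 3 (within the scatter)). Methyl in place of hydrogen on an aromatic nitrogen can also be read for the first time, with the methoxy group present (a number 1 percentage points lower from compound 1 to compound 3 (within the scatter)). Neither single change therefore separates these compounds on this read-out, and nothing available offers an explanation for these results.

Going by these compounds, it remains open whether an amine, a carboxylic acid or a longer chain on this aromatic carbon would give a number beyond the scatter. On these data alone, it is equally open whether an ethyl or benzyl group on the aromatic nitrogen would do so.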